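A few compounds are considered here, and "the series" means these few. Any claim that something is new, unique, unknown or untested is made for them only; others in the source may bear on it.

Measured compounds in the series:

Compound 1 `CC(=O)N1N=C(c2cc3ccccc3nc2C)CC1/C=C/c1ccccc1`: 93.3 ug/mL
Compound 2 `CC(=O)N1N=C(c2cc3ccccc3nc2C)CC1c1ccc(Oc2nc(Cl)c(Cl)cc2Cl)cc1`: > 200 ug/mL, a limit of the assay, not a number
Compound 3 `CC(=O)N1N=C(c2cc3ccccc3nc2C)CC1c1ccc(N(C)C)cc1`: 110 ug/mL

All three were read in an ADME assay on A549 cells (Homo sapiens) for cytotoxicity, read by MTT assay, with a stated time of 48 h; a lower number here means a stronger inhibitor, a higher number a weaker inhibitor. Compound 3 and compound 1 sit within the scatter of each other, the step being a 1.2-fold higher number from compound 1 to compound 3 (0.07 log units; within the scatter). Compound 2 gives only a limit, as described by the limit of > 200 ug/mL in this assay, at which 1 of the 3 values shown sits. Among the compounds with values here, the step of an at least 1.8-fold lower number from compound 2 to compound 3 (0.25 log units; that floor lies within the scatter) therefore has a floor that also lies within the scatter, so nothing measured so far separates compound 3 from its neighbours.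

Compound 4 `COc1ccc(C2CC(c3cc4ccccc4nc3C)=NN2C(C)=O)cc1` differs from compound 3 only at the aromatic carbon para to the large group: methoxy in place of dimethylamino on an aromatic carbon. Within the data shown here, no measured step swaps a methoxy for any group, so no direct precedent exists. The two steps that end at compound 3, a 1.2-fold higher number from compound 1 to compound 3 (0.07 log units; within the scatter) and an at least 1.8-fold lower number from compound 2 to compound 3 (0.25 log units; that floor lies within the scatter), each change a much larger group at the same position than the change to compound 4 does, and neither moves the number beyond the scatter. The expectation for the step from compound 3 to compound 4 is accordingly none beyond the scatter, a 1.0-fold higher number from compound 3 to compound 4 (0.02 log units; within the scatter). Compound 4 is estimated at 115 ug/mL in this assay, with a range from 55 ug/mL to 200 ug/mL.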

Compound 4, half-maximal inhibitory concentration: 116 ug/mL
Compound 4: the middle estimate sits 1.0-fold (0.00 log units) below what was measured; the measured number falls inside the stated range.
By their numbers in this assay, from the lowest: compounds 1, 3 and 4 (each within the scatter of the next). At a limit, above all of these: compound 2.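

Within the data shown here, at the aromatic carbon para to a large group, the earlier steps changed whole large groups, whereas here one small group replaces another, dimethylamino giving way to methoxy with the ring kept and one hydrogen-bond acceptor on each side, and in this assay this reads as a 1.1-fold higher number from compound 3 to compound 4 (0.02 log units; within the scatter). The 4-methoxyphenyl group in place of 2-phenylethenyl on a saturated ring carbon gives a 1.2-fold higher number from compound 1 to compound 4 (0.09 log units; within the scatter), so a second aryl group at that carbon also stays within the scatter of compound 1, and compounds 1, 3 and 4 cannot be told apart in this assay. The remaining step reads only as a floor, an at least 1.7-fold lower number from compound 2 to compound 4 (0.23 log units; that floor lies within the scatter), with the entry for compound 2 a limit of the assay and not a number: the limit of > 200 ug/mL in this assay, at which 1 of the 4 values shown sits.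

On these data alone, whether a carboxylic acid, a primary amine or a longer alkoxy chain at this aromatic carbon would move the number beyond the scatter remains open. Also open, as far as these compounds go, is whether the same small exchange of dimethylamino for methoxy would stay within the scatter on a different core.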